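Methoxy to methyl: expected half-life of compound 3

A few compounds are considered here, and "the series" means these few. Any claim that something is new, unique, unknown or untested is made for them only; others in the source may bear on it.

Measured so far in an ADME assay on microsomes from liver (Homo sapiens) for metabolic stability (a higher number here means that the compound lasts longer, a lower number that the compound disappears faster), for the series:
- compound 1 `O=C(Nc1cccc(-c2nc3ccccc3s2)c1)c1cc([N+](=O)[O-])ccc1Cl` gives 1 h
- compound 2 `COc1ccc(-c2nc3ccccc3s2)cc1NC(=O)c1cc([N+](=O)[O-])ccc1Cl` gives 3.7 h

Compound 2 stands highest of the two at 3.7 h and is the starting point here. The change to compound 3 `Cc1ccc(-c2nc3ccccc3s2)cc1NC(=O)c1cc([N+](=O)[O-])ccc1Cl` is methyl in place of methoxy on an aromatic carbon. Among the measured compounds shown here, one measured step bears on it: a 3.7-fold higher number from compound 1 to compound 2 (0.57 log units; beyond the scatter) for methoxy in place of hydrogen, modest but beyond the scatter. For the measured compounds named here, no measured compound carries methyl, so the loss of part of that gain is only an expectation. The expected move in this assay is a small one downward (a 1.7-fold lower number from compound 2 to compound 3 (0.23 log units; within the scatter)). Compound 3 is estimated at 2.2 h with an expected range of 1 h to 5 h in this series.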

Compound 3, half-life: > 4 h
Compound 3: a limit, no number (the forecaster's own chance of this, stated with the estimate: 3%); at least 1.8-fold (0.25 log units) between middle value and limit.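

In this assay compound 3 gives > 4 h, a limit and not a number: the limit of > 4 h in this assay, at which 1 of the 3 values shown sits. Against hydrogen at this position, methyl brings a rise beyond the scatter, an at least 4.0-fold higher number from compound 1 to compound 3 (0.60 log units; beyond the scatter), so the oxygen of methoxy is not required for a gain here. The exchange of methoxy for methyl gives an at least 1.0-fold higher number from compound 2 to compound 3 (0.03 log units; that floor lies within the scatter), so no order of these two groups can be read. From the compounds shown here alone, the true half-life of compound 3 remains open. So does the effect in this assay of a larger or different group at this position, such as ethyl or an amine.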